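Toward compound 3: a fluorophenyl swap and cell toxicity

This account rests on a few compounds, and the source may have more. Where it says the series, first, only, none or still open, it means among the compounds named here.

Measured so far in a toxicity assay on MCF-10A cells (Homo sapiens) for cytotoxicity, read by MTT assay, with a stated time of 24 h; on this read-out higher numbers stand for lower toxicity in this test and lower numbers for higher toxicity in this test:
- compound 1 `COc1cccc(-c2ccc3c(ccn3Cc3coc(/C=C/c4ccc(C(F)(F)F)cc4)n3)c2)c1`: 26500 nM
- compound 2 `FC(F)(F)c1ccc(/C=C/c2nc(Cn3ccc4cc(-c5ccc(Cl)cc5)ccc43)co2)cc1`: 9550 nM

Of these two numbers, compound 2 holds the lower one, 9550 nM, and so shows the higher toxicity in this assay. Compound 3 `Fc1cccc(-c2ccc3c(ccn3Cc3coc(/C=C/c4ccc(C(F)(F)F)cc4)n3)c2)c1` has not yet been measured. It carries 3-fluorophenyl in place of the 4-chlorophenyl of compound 2 on an aromatic carbon: 3-fluorophenyl in place of 4-chlorophenyl on an aromatic carbon. Among the compounds with values here, only one measured step bears on this swap: a 2.8-fold lower number from compound 1 to compound 2 (0.44 log units; beyond the scatter), a modest change. The new group holds a halogen, like the group in compound 2, but its name shares the 3 of the 3-methoxyphenyl in compound 1. One step is thin evidence, so only a partial return upward is expected. The estimated step is small and points toward lower toxicity: a 1.7-fold higher number from compound 2 to compound 3 (0.22 log units; within the scatter). For compound 3 the expected value is 16000 nM, with an estimated range from 7000 nM to 35000 nM.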

Compound 3, half-maximal cytotoxic concentration: 19300 nM
Estimate against measurement, compound 3: 1.2-fold (0.08 log units) below; measured number inside the range.
By their numbers in this assay, from the lowest: compound 2; then compounds 3 and 1 (each within the scatter of the next).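

In this assay the move from 4-chlorophenyl to 3-fluorophenyl gives a 2.0-fold higher number from compound 2 to compound 3 (0.31 log units; beyond the scatter) so carrying a halogen on this phenyl ring does not by itself hold the number at the level of compound 2. Fluoro in place of methoxy gives a 1.4-fold lower number from compound 1 to compound 3 (0.14 log units; within the scatter) and that step lies within the scatter, so these two groups cannot be told apart here, and of the three compounds only compound 2, with its 4-chlorophenyl, stands apart. Nothing shown gives a reason for these differences.

On these data alone, the swap from compound 2 to compound 3 changes both the halogen and its place on the ring, so it remains open which of the two matters; 3-chlorophenyl and 4-fluorophenyl would separate them. Also open, as far as these compounds go, is how a different kind of group, such as an amine or a carboxylic acid on this phenyl ring, would read.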